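The source may report more compounds than this note shows. Statements on the series, on what has been measured and on what is new or still open speak of the compounds shown alone.

Measured so far in an in vivo ADME assay on the whole organism for metabolic stability, with Mus musculus as the target, read by LC-MS, at a dose of 160 mg/kg by the oral route; a higher number here means that the compound lasts longer, a lower number that the compound disappears faster:
compound 1, `CC(C)(C)N1CC(=O)N=C1NC(=N)Nc1ccc(Cl)c(Cl)c1`: > 1 h.
compound 2, `CC(C)(C)OC(=O)/N=C(\NC1=NC(=O)CN1C(C)(C)C)Nc1ccc(Cl)c(Cl)c1`: < 0.167 h.

For compound 2 the value is a limit of the assay, not a number; it sits at the limit of < 0.167 h in this assay, at which 1 of the 2 values shown sits. For compound 1 the value is also a limit, sitting at the limit of > 1 h in this assay, at which 1 of the 2 values shown sits. Going by the values given here, compound 1 thus stands on a limit only, and the one other value shown is a limit as well, so the two values show nothing more than their two ends, and no step between these two compounds is counted.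

Compound 3, `CC(C)N1CC(=O)N=C1NC(=N)Nc1ccc(Cl)c(Cl)c1`, is not yet measured. It differs from compound 1 by hydrogen in place of methyl on a saturated chain carbon bound to an amine nitrogen in a ring and two saturated chain carbons; cut one bond further out, the change reads tert-butyl to isopropyl. Among the compounds with values here, no measured pair shows the effect of such a change, so in this assay the step is expected to stay within the scatter, with no direction favoured. The expected step is a step that the limit leaves unreadable from compound 1 to compound 3. Compound 3 is estimated at 1.5 h, with a range from 0.6 h to 4 h, and a fair chance that the assay again reports only a limit.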

Compound 3, half-life: 0.667 h
For compound 3 the middle estimate is 2.2-fold (0.35 log units) above the measured one, and the stated range covers the measured number.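

In this assay, going by these compounds alone, compound 3 gives 0.667 h, the first value that is a number and not a limit. At this position, the change from tert-butyl to isopropyl gives an at least 1.4-fold lower number from compound 1 to compound 3 (0.17 log units; that floor lies within the scatter), so its size is bounded from one side only. On these data alone, the upper end of that step stays unknown because compound 1 stands on a limit: the limit of > 1 h in this assay, at which 1 of the 3 values shown sits.

As far as these compounds go, whether the true step from tert-butyl to isopropyl lies beyond the scatter remains open, and a number for compound 1 would be needed to settle it. Within the data shown here, also open is how the half-life responds at this place to other groups, such as ethyl, cyclopropyl or a longer chain, since only two groups at this position can be compared here.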